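This account rests on a few compounds, and the source may have more. Where it says the series, first, only, none or still open, it means among the compounds named here.

Compound 1 `COc1ccc(Cn2cnc3c(Nc4cccc(Cl)c4)nc(N[C@H]4CC[C@H](N)CC4)nc32)cc1` gives 18700 nM 
Compound 2 `CCCCCCn1cnc2c(Nc3cc(OC)cc(OC)c3)nc(N[C@H]3CC[C@H](N)CC3)nc21` gives 9100 nM 

In a functional assay on HCC827 cells (Homo sapiens) for inhibition, read by fluorescence, with a stated time of 72 h (a lower number here means a stronger inhibitor of growth, a higher number a weaker inhibitor of growth), compound 2, at 9100 nM, holds the lower of the two numbers, a small gap from compound 1 but beyond the scatter. Compound 3 `CCCCCCn1cnc2c(Nc3cccc(Cl)c3)nc(N[C@H]3CC[C@H](N)CC3)nc21` carries 3-chlorophenyl in place of 3,5-dimethoxyphenyl on a nitrogen on an aromatic ring. Among the measured compounds shown here, no single-change step has been measured, and compound 1, which also carries 3-chlorophenyl, differs from compound 3 elsewhere too. The estimated step of a 1.1-fold higher number from compound 2 to compound 3 (0.04 log units; within the scatter) is expected to stay within the scatter, with no direction favoured. The expected value for compound 3 is 10000 nM (estimated range 4000 nM to 22000 nM).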

Compound 3, concentration for 50% growth inhibition: 10200 nM
For compound 3 the middle estimate is 1.0-fold (0.01 log units) below the measured one; the measured number falls inside the stated range.
By their numbers in this assay, from the lowest: compounds 2, 3 and 1 (each within the scatter of the next, the first and the last beyond it).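

In this assay, exchanging 3,5-dimethoxyphenyl for 3-chlorophenyl on a nitrogen on an aromatic ring gives a step within the scatter (a 1.1-fold higher number from compound 2 to compound 3 (0.05 log units; within the scatter)), so the two oxygen-bearing methoxy groups can go without a measurable change in this pair. Pentyl in place of 4-methoxyphenyl on a saturated chain carbon bound to an aromatic nitrogen also stays within the scatter (a 1.8-fold lower number from compound 1 to compound 3 (0.26 log units; within the scatter)). No evidence accompanies these results to explain them.

From the compounds shown here alone, it remains open whether an amine or a carboxylic acid on the aromatic ring, or a longer chain at the other position, would shift growth inhibition beyond the scatter.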